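Swapping Allyl for Benzyl: Expected Cytotoxicity of Compound 4

This account rests on a few compounds, and the source may have more. Where it says the series, first, only, none or still open, it means among the compounds named here.

Compound 1 `C=CCN1[C@@H](c2ccccn2)CC(O)=C(C(=O)OC)[C@H]1c1ccccn1` gives 35 uM in an ADME assay on J774.1 cells (Mus musculus) for cytotoxicity, with a stated time of 48 h; on this read-out lower numbers stand for an effect already at smaller amounts and higher numbers for an effect only at larger amounts of compound.
Compound 2 `COC(=O)C1C(=O)C(C(=O)OC)[C@H](c2ccccn2)N(CCCC(=O)O)[C@@H]1c1ccccn1` gives 46 uM in this assay.
Compound 3 `COC(=O)C1C(=O)[C@H](C(=O)OC)C(c2ccccn2)N[C@@H]1c1ccccn1` reaches only a limit of this assay, > 100 uM.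

Among the two plain numbers, compound 1 sits lowest, and compound 2 is nearest to it, but the gap between them lies within the usual scatter of this assay, so no order between them can be claimed. Compound 4 `COC(=O)C1=C(O)C[C@H](c2ccccn2)N(Cc2ccccc2)[C@@H]1c1ccccn1` has not yet been measured in this assay. It differs from compound 1 by phenyl in place of vinyl on a saturated chain carbon bound to an amine nitrogen in a ring. For the measured compounds named here, no measured pair shows this same change, so its size is a guess. The step from compound 1 to compound 4 is expected to be a 1.4-fold lower number from compound 1 to compound 4 (0.15 log units; within the scatter), a slight shift toward an effect at smaller amounts and not clearly beyond the scatter. For compound 4 the estimated value is 25 uM, with a range from 10 uM to 70 uM.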

Compound 4, concentration for half-maximal effect: 33.2 uM
Compound 4: the middle estimate sits 1.3-fold (0.12 log units) below what was measured; the measured number falls inside the stated range.
By their numbers in this assay, from the lowest: compounds 4, 1 and 2 (each within the scatter of the next). At a limit, above all of these: compound 3.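

On a saturated chain carbon bound to an amine nitrogen in a ring, phenyl in place of vinyl gives a 1.1-fold lower number from compound 1 to compound 4 (0.02 log units; within the scatter) in this assay. Allyl and benzyl therefore cannot be told apart at this position in this read-out, something the earlier compounds could not show, as no two of them differed in only one place.

Going by these compounds, whether a benzyl carrying an amine, or a longer chain ending in phenyl, would shift the number remains open. Nothing measured here bears on the reason for this result.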